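Removing the amine from a soluble ester: compound 2 to compound 3

The compounds below may be only part of what the source reports. "The series", "measured", "known", "first", "only" and "open" are said of these compounds alone.

Measured compounds:
compound 1, `Cc1c(C)c2c(c(C)c1OC(=O)CCN)CC(CCn1ccc(=O)c(O)c1C)O2`, 10000 ug/mL
compound 2, `Cc1c(OC(=O)CCN)c(=O)ccn1CCCc1cc(C(C)(C)C)c(O)c(C(C)(C)C)c1`, > 20000 ug/mL

This account concerns two esters measured in an ADME assay for solubility; a higher number here means a more soluble compound, a lower number a less soluble compound. Compound 1 gives 10000 ug/mL in this assay. For compound 2 the reading of > 20000 ug/mL is a limit of the assay and not a number, as one of the two values shown sits at the limit of > 20000 ug/mL in this assay, at which 1 of the 2 values shown sits. Among the compounds with values here, no step between the two measured compounds is available, since they differ in more than one place, and their two values are merely what each compound shows on its own.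

The unmeasured compound 3, `CC(=O)Oc1c(C)n(CCCc2cc(C(C)(C)C)c(O)c(C(C)(C)C)c2)ccc1=O`, differs from compound 2 in one place: hydrogen in place of aminomethyl on a saturated chain carbon bound to a carbonyl carbon. With compound 2 standing at a limit, the step from compound 2 to compound 3 is expected to be a decrease in solubility well beyond the scatter, an at least 66-fold lower number from compound 2 to compound 3 (1.82 log units; beyond the scatter). Compound 3 is therefore estimated at 300 ug/mL, within a range from 30 ug/mL to 3000 ug/mL.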

Compound 3, solubility: < 100 ug/mL
Compound 3 was reported as a limit; the forecaster's own chance of this, stated with the estimate: 10%; at least 3.0-fold (0.47 log units) between middle value and limit.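

Replacing aminomethyl with hydrogen on a saturated chain carbon bound to a carbonyl carbon, a single change at this position, gives an at least 200-fold lower number from compound 2 to compound 3 (2.30 log units; beyond the scatter) in this assay, a step that the two earlier compounds, differing in more than one place, could not show. The reading for compound 3 is a limit and not a number: the limit of < 100 ug/mL in this assay, at which 1 of the 3 values shown sits. The reading for compound 2 is also a limit and not a number: the limit of > 20000 ug/mL in this assay, at which 1 of the 3 values shown sits.

From the compounds shown here alone, with a limit at each end, the full size of this step stays open. Also open, going by these compounds, is what a longer chain carrying an amine, or a carboxylic acid in place of the amine, would read at this position, and whether the same change on the core of compound 1 would give a comparable step.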